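The source may hold more compounds than are shown below. What is called first, only, known or untested is meant among the compounds shown, and "the series" means these compounds.

Working notes on the series. Compound 1 `Cc1cc(-c2sc(Cc3cccc(F)c3)nc2C)ccc1C(N)=O` and compound 2 `Cc1cc(-c2sc(Cc3cccc(Cl)c3)nc2C)ccc1C(N)=O` share one core and differ only in the halogen on the benzyl ring. In a functional assay on cells for agonist activity at G-protein coupled receptor 52 (Homo sapiens), read by AlphaScreen and cAMP accumulation, with a stated time of 30 min (a lower number here means a smaller maximal response, a higher number a larger maximal response), compound 1 gives 75%, and in this assay compound 2 gives 75%. The step of no change at the digits printed from compound 1 to compound 2 (within the scatter) shows that chloro in place of fluoro on an aromatic carbon leaves the maximal response where it was. Among the measured compounds shown here, compound 2 therefore stands level with compound 1 on the single value measured for it, with no other neighbour to compare against.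

Compound 3 `Cc1cc(-c2sc(Cc3ccc(Cl)cc3)nc2C)ccc1C(N)=O` is the next point. It differs from compound 2 by 4-chlorophenyl in place of 3-chlorophenyl on a saturated chain carbon bound to an aromatic carbon. For the measured compounds named here, no measured step moves a substituent around the benzyl ring; the only step on hand, from compound 1 to compound 2, swaps one halogen for another in the same position and was flat. The expected step of a number 3 percentage points lower from compound 2 to compound 3 (within the scatter) is accordingly set close to nil, with a wider range to allow for an untested kind of change. For compound 3 the maximal response in this assay is estimated at 72%, within 50% to 92%.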

Compound 3, largest response reached (Emax), in percent of the reference or control that the assay uses: 60%
Compound 3: middle estimate off by 12 percentage points, on the high side, within the range that was stated.
By their numbers in this assay, from the lowest: compound 3; then compounds 1 and 2 (each within the scatter of the next).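

Moving the chlorine is the first change in the series that shifts the maximal response in this assay: 3-chlorobenzyl to 4-chlorobenzyl gives a number 15 percentage points lower from compound 2 to compound 3 (beyond the scatter), although the two compounds have the same atoms joined differently. The change of both halogen and ring substitution, 4-chlorophenyl in place of 3-fluorophenyl, gives a step of the same size, a number 15 percentage points lower from compound 1 to compound 3 (beyond the scatter), so among these three compounds 3-fluorophenyl and 3-chlorophenyl stand level and 4-chlorophenyl alone departs from them. Nothing on hand accounts for this drop, and the numbers describe it without explaining it.

With one compound carrying 4-chlorophenyl, the compounds shown leave open whether the lower response belongs to the chlorine in particular or would also appear with 4-fluorophenyl, and whether a methoxy group or a nitrile in the same place would follow it. They also leave open how an unsubstituted phenyl on the same saturated chain carbon would compare, and whether any of these steps would hold on a core in which a carboxylic acid replaces the primary amide.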